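A few compounds are considered here, and "the series" means these few. Any claim that something is new, unique, unknown or untested is made for them only; others in the source may bear on it.

Measured in a functional assay on HeLa cells (Homo sapiens) for antiproliferative activity, read by CCK-8 assay, with a stated time of 72 h, tested at 2 uM; a higher number here means a stronger effect of the compound at the concentration tested, a lower number a weaker effect:
compound 1 `Nc1ccccc1NC(=O)c1ccc(CSC(=S)N2CCN(c3cccnc3)CC2)cc1`: 66.2%
compound 2 `CC1CCCCN1C(=S)SCc1ccc(C(=O)Nc2ccccc2N)cc1`: 45.5%
compound 3 `CC1CCN(C(=S)SCc2ccc(C(=O)Nc3ccccc3N)cc2)CC1`: 46.8%

Compound 1 gives the highest of the three numbers in this assay; compound 3 and compound 2 both sit below it by more than the scatter, and the two of them lie within the scatter of each other. Compound 4 `Nc1ccccc1NC(=O)c1ccc(CSC(=S)N2CCN(Cc3cccnc3)CC2)cc1` differs from compound 1 by (pyridin-3-yl)methyl in place of pyridin-3-yl on an amine nitrogen in a ring. Within the data shown here, no measured step bears on this change. Among the measured compounds shown here, the one step in hand, a number 1.3 percentage points higher from compound 2 to compound 3 (within the scatter), concerns a different place in the shared core and lies within the scatter, so it gives no guide to what a change at the amine nitrogen in the ring does. The step expected here is therefore a number 8.2 percentage points lower from compound 1 to compound 4 (within the scatter), a change not clearly beyond the scatter in either direction. Compound 4 is estimated at 58%, with a range from 40% to 75%.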

Compound 4, a percentage reported as inhibition, at one concentration (the size of the read-out at that concentration, not a potency): 69.7%
Compound 4: middle estimate off by 11.7 percentage points, on the low side; measured number inside the range.
By their numbers in this assay, from the lowest: compounds 2 and 3 (each within the scatter of the next); then compounds 1 and 4 (each within the scatter of the next).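

In this assay, (pyridin-3-yl)methyl in place of pyridin-3-yl on the amine nitrogen in the ring gives a number 3.5 percentage points higher from compound 1 to compound 4 (within the scatter). Among these compounds, this is the first step read at this position, and it shows that the position takes this change without a shift beyond the scatter. No measured evidence bears on the reason for this result.

As far as these compounds go, whether a longer chain carrying the pyridine ring, or a phenyl or acetyl group on the same nitrogen, would give a similar number remains open. The single tested concentration also leaves potency open.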